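Cyano substitution on two diazabicyclic pyridinyl agonist cores

The source may hold more compounds than are shown below. What is called first, only, known or untested is meant among the compounds shown, and "the series" means these compounds.

Compound 1 `c1cncc(N2CC[C@@H]3CN[C@@H]3C2)c1` is the parent of the first core; in a functional assay on HEK293 cells for agonist activity at Neuronal acetylcholine receptor; alpha4/beta2 (Homo sapiens), read by FLIPR (on this read-out lower numbers stand for an effect already at smaller amounts and higher numbers for an effect only at larger amounts of compound), compound 1 gives 330 nM. Compound 2 `N#Cc1cncc(N2CC[C@@H]3CN[C@@H]3C2)c1` carries a cyano group on that core, and in this assay compound 2 gives 1900 nM. The change from compound 1 to compound 2 is cyano in place of hydrogen on an aromatic carbon, and it produces a 5.8-fold higher number from compound 1 to compound 2 (0.76 log units; beyond the scatter).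

Compound 3 `c1cncc(N2C[C@@H]3CCNC[C@@H]32)c1` is the parent of the second core, built from the same atoms as compound 1 but joined differently; the difference between the two cores is not broken down here. In this assay compound 3 gives 410 nM, a value within the scatter of that of compound 1, so the two parents cannot be ranked against each other.

Compound 4 `N#Cc1cncc(N2C[C@@H]3CCNC[C@@H]32)c1` is not yet measured. It differs from compound 3 by cyano in place of hydrogen on an aromatic carbon, the same change, at the same place, as that from compound 1 to compound 2. Among the measured compounds shown here, with only one prior instance of this change, the expectation for compound 4 rests on that single step: the estimated shift is a 5.9-fold higher number from compound 3 to compound 4 (0.77 log units; beyond the scatter), on the grounds that the same change gave a 5.8-fold higher number from compound 1 to compound 2 (0.76 log units; beyond the scatter) and that the parents compound 1 and compound 3 sit close together. Compound 4 is thus expected to give about 2400 nM in this assay, with a plausible range from 1100 nM to 5200 nM.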

Compound 4, half-maximal effective concentration: 2190 nM
The estimate for compound 4 lay 1.1-fold (0.04 log units) above the measured number; the measured number falls inside the stated range.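

In this assay, cyano in place of hydrogen on an aromatic carbon also moves the core of compound 3 towards effects only at larger amounts of compound, giving a 5.3-fold higher number from compound 3 to compound 4 (0.73 log units; beyond the scatter). Set beside the earlier step, the change carries from one core to the other with a size that cannot be told apart between the two: the same change on two cores in this assay, a 5.8-fold higher number (0.76 log units; beyond the scatter) from compound 1 to compound 2 and a 5.3-fold higher number (0.73 log units; beyond the scatter) from compound 3 to compound 4, 1.1-fold (0.03 log units) apart, within the scatter of two such steps This agreement rests on only two cores, one ring carbon and one read-out, so it shows that the step transfers between this pair of cores, but not that it would transfer to any other core, and it gives no explanation of why the step has this size.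

The compounds shown leave open whether a chlorine atom, a methoxy group or an amine on the same aromatic carbon, two atoms from the ring nitrogen, would shift the number in the same direction and by a similar amount as cyano. They also leave open whether cyano on a different carbon of the aromatic ring would give a similar step on either core.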